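Adding One Methyl to Compound 1

A few compounds are considered here, and "the series" means these few. Any claim that something is new, unique, unknown or untested is made for them only; others in the source may bear on it.

In a functional assay on MCF7 cells (Homo sapiens) for inhibition, read by resazurin assay, with a stated time of 24 h (on this read-out higher numbers stand for weaker inhibition and lower numbers for stronger inhibition), compound 1 `O=C1Nc2c(C(F)(F)F)cccc2C1(c1ccc(O)cc1)N1CCC(F)(F)CC1` gives 35 nM. Compound 3 `O=C1Nc2c(C(F)(F)F)cccc2[C@]1(c1ccc(OC(F)(F)F)cc1)c1ccc(O)c(O)c1` gives 24 nM, and the values of these two compounds lie within the usual scatter of each other. Compound 2 `O=C1Nc2c(C(F)(F)F)cccc2C1(c1ccc(OC(F)(F)F)cc1)c1ccc(OC(F)(F)F)cc1` reads > 1000 nM, and this entry is a limit of the assay and not a number.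

Compound 4 `CC1CN(C2(c3ccc(O)cc3)C(=O)Nc3c(C(F)(F)F)cccc32)CCC1(F)F` keeps the core of compound 1 and differs from it in one place. It carries methyl in place of hydrogen on a saturated ring carbon, next to the ring atom that bears two fluoro groups and two ring bonds from the ring nitrogen (methyl in place of hydrogen on a saturated ring carbon).

Going by the values given here, no pair of measured compounds here differs in one place, so the data give no direct reading of what this methyl does. In this assay, the expected step is therefore none beyond the scatter, though a slight move towards a higher number would not surprise. This expectation starts from compound 1 at 35 nM and from the small size of the change. The expected change is a 1.4-fold higher number from compound 1 to compound 4 (0.15 log units; within the scatter). For compound 4 the estimated value is 50 nM, with an expected range from 15 nM to 180 nM.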

Compound 4, half-maximal inhibitory concentration: 70 nM
The estimate for compound 4 lay 1.4-fold (0.15 log units) below the measured number; the range from low to high includes it.
By their numbers in this assay, from the lowest: compounds 3, 1 and 4 (each within the scatter of the next, the first and the last beyond it). At a limit, above all of these: compound 2.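

Going by these compounds alone, the methyl on this saturated ring carbon gives the first direct reading of a change at this position, since no earlier pair of compounds differed in one place: in this assay, it brings a 2.0-fold higher number from compound 1 to compound 4 (0.30 log units; within the scatter). As this step lies within the scatter, the data do not show that adding a methyl at this ring carbon, next to the ring atom that bears two fluoro groups, alters the reading, and this position therefore accepts the methyl without a change that can be told apart from repeated measurement. Nothing measured here bears on why the reading came out this way, and the limit reached by another compound says nothing about this position.

The compounds shown leave open whether a larger group at this ring carbon, such as an ethyl, a hydroxymethyl or an amine, would also stay within the scatter of compound 1 or would move the number beyond it. They also leave open whether a methyl on the other ring carbons would read the same way, and whether the two spatial arrangements at this carbon, which the structure of compound 4 does not specify, would read alike.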